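The source may hold more compounds than are shown below. What is called first, only, known or untested is meant among the compounds shown, and "the series" means these compounds.

Compound 1 `Nc1scc(CN2CCN(c3cc(Cl)cc(Cl)c3)CC2)c1C(=O)c1ccc(Cl)cc1`: 1%
Compound 2 `Nc1scc(CN2CCN(c3ccc(Cl)c(C(F)(F)F)c3)CC2)c1C(=O)c1ccc(Cl)cc1`: 0%
Compound 3 `Nc1scc(CN2CCN(c3cccnc3)CC2)c1C(=O)c1ccc(Cl)cc1`: 0%

In an assay on CHO cells for displacement of a labelled ligand from adenosine receptor A1 (Homo sapiens), read by scintillation counting, with a stated time of 120 min, tested at 10 uM (on this read-out lower numbers stand for less inhibition and higher numbers for more inhibition at the one concentration tested (going by the name of the read-out)), compound 1 gives 1%, the highest of the three numbers, but only by a margin that the scatter swallows: a number 1 percentage points lower from compound 1 to compound 2 (within the scatter) and a number 1 percentage points lower from compound 1 to compound 3 (within the scatter). Compound 2 and compound 3 sit together as well, with no change at the digits printed from compound 2 to compound 3 (within the scatter). Compound 4 `Nc1scc(CN2CCN(c3c(F)cccc3F)CC2)c1C(=O)c1ccc(Cl)cc1` carries the change (2,6-difluorophenyl in place of 3,5-dichlorophenyl on an amine nitrogen in a ring). The two steps that bear on it, from compound 1 to compound 2 and from compound 1 to compound 3, both swap the group on the ring nitrogen and both stay flat, so no step beyond the scatter is expected here either. Compound 4 is therefore expected to give 1%, somewhere between -5% and 8%, a step of no change at the digits printed from compound 1 to compound 4 (within the scatter).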

Compound 4, a percentage reported as inhibition, at one concentration (the size of the read-out at that concentration, not a potency): 1%
The estimate for compound 4 equals the measured number at the digits printed; the measured number falls inside the stated range.
By their numbers in this assay, from the lowest: compounds 2, 3, 1 and 4 (each within the scatter of the next).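

In this assay, a phenyl carrying only fluorine on the ring nitrogen behaves like the chlorine-bearing phenyls and pyridin-3-yl (no change at the digits printed from compound 1 to compound 4 (within the scatter); a number 1 percentage points higher from compound 3 to compound 4 (within the scatter); a number 1 percentage points higher from compound 2 to compound 4 (within the scatter)). The 2,6-difluorophenyl group thus extends the flat picture at this position to a fourth aromatic ring pattern, and none of the four groups lifts the number out of the scatter. The compounds shown leave open whether a benzyl group or an alkyl chain on this nitrogen would do so. Nothing at hand accounts for this flat read-out.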